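This account rests on a few compounds, and the source may have more. Where it says the series, first, only, none or still open, it means among the compounds named here.

Series notes. Compound 1 `COc1cccc(NC(=O)COc2ccc3cc(/C=C4/SC(=O)NC4=O)ccc3c2)c1` and compound 2 `Cc1cccc2sc(NC(=O)COc3ccc4cc(/C=C5/SC(=O)NC5=O)ccc4c3)nc12` share their core with compound 3 `O=C(COc1ccc2cc(/C=C3/SC(=O)NC3=O)ccc2c1)Nc1ccc(Br)c(Br)c1` and differ only in the group on an amide-type nitrogen. In an assay on isolated protein for inhibition of histone deacetylase 8 (Homo sapiens), with a stated time of 1 h (a lower number here means a stronger inhibitor, a higher number a weaker inhibitor), compound 1 gives 7600 nM and compound 2 gives 5800 nM; the step of a 1.3-fold lower number from compound 1 to compound 2 (0.12 log units; within the scatter) stays within the scatter. Compound 3 gives only a limit in this assay, > 50000 nM. Both routes into compound 3 lose potency: an at least 6.5-fold higher number from compound 1 to compound 3 (0.81 log units; beyond the scatter) and an at least 8.6-fold higher number from compound 2 to compound 3 (0.93 log units; beyond the scatter). Compound 3 thus stands at the limit of > 50000 nM in this assay, at which 1 of the 3 values shown sits. Compound 4 `O=C(COc1ccc2cc(/C=C3/SC(=O)NC3=O)ccc2c1)Nc1ccc(F)cc1F` follows: 2,4-difluorophenyl in place of 3,4-dibromophenyl on an amide-type nitrogen. Among the measured compounds shown here, the steps that bear on it are the two into compound 3, each only a move from a number to a limit, so a partial recovery toward the values of compound 1 and compound 2 is expected, an at least 3.3-fold lower number from compound 3 to compound 4 (0.52 log units; beyond the scatter). Compound 4 is estimated at 15000 nM in this assay, between 5000 nM and 50000 nM.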

Compound 4, half-maximal inhibitory concentration: > 50000 nM
Compound 4 was reported as a limit; the forecaster's own chance of this, stated with the estimate: 30%; middle value at least 3.3-fold (0.52 log units) away from the limit.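

In this assay compound 4 gives only a limit, as compound 3 does, so the step between them cannot be read. The change from 3,4-dibromophenyl to 2,4-difluorophenyl therefore brings no readable recovery, and the loss against the other two groups remains, with an at least 8.6-fold higher number from compound 2 to compound 4 (0.93 log units; beyond the scatter) and an at least 6.5-fold higher number from compound 1 to compound 4 (0.81 log units; beyond the scatter). Two dihalophenyl amides now share the limit: the limit of > 50000 nM in this assay, at which 2 of the 4 values shown sit.

From the compounds shown here alone, whether compound 3 and compound 4 differ at all in this assay stays open. So does whether a phenyl carrying an amine or a carboxylic acid would restore a measurable number.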